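Dimethylphenyl Analogue Expected to Lose Potency

The source may hold more compounds than are shown below. What is called first, only, known or untested is meant among the compounds shown, and "the series" means these compounds.

For the measured compounds named here, compound 2 `COc1cc(Nc2ncc(C(F)(F)F)c(N3Cc4cccc(N(C)S(C)(=O)=O)c4C3)n2)cc(OC)c1` holds the only number in a functional assay on HepG2 cells (Homo sapiens) for antiproliferative activity, read by spectrophotometry, with a stated time of 2 days (a lower number here means a stronger inhibitor of growth, a higher number a weaker inhibitor of growth), giving 1800 nM. For compound 1 `Cc1ccc(Nc2ncc(C(F)(F)F)c(N3Cc4cccc(N(C)S(C)(=O)=O)c4C3)n2)c(Cl)c1` this assay reports only a limit, > 30000 nM, which is the limit of > 30000 nM in this assay, at which 1 of the 2 values shown sits. Going by the values given here, the one measured step, an at least 16-fold lower number from compound 1 to compound 2 (1.22 log units; beyond the scatter), bears on compound 3 `Cc1ccc(Nc2ncc(C(F)(F)F)c(N3Cc4cccc(N(C)S(C)(=O)=O)c4C3)n2)c(C)c1`, which differs from compound 2 by 2,4-dimethylphenyl in place of 3,5-dimethoxyphenyl on a nitrogen on an aromatic ring. The entering group resembles that of compound 1 rather than that of compound 2. A large rise in this assay is therefore expected, an 11-fold higher number from compound 2 to compound 3 (1.05 log units; beyond the scatter). Compound 3 is estimated at 20000 nM, within a range from 5000 nM to 60000 nM, and a limit alone is possible.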

Compound 3, concentration for 50% growth inhibition: 19100 nM
For compound 3 the middle estimate is 1.0-fold (0.02 log units) above the measured one; measured number inside the range.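

Moving from 3,5-dimethoxyphenyl to 2,4-dimethylphenyl on this nitrogen gives an 11-fold higher number from compound 2 to compound 3 (1.03 log units; beyond the scatter), so the large loss also occurs without a chloro group. Methyl in place of chloro gives an at least 1.5-fold lower number from compound 1 to compound 3 (0.19 log units; that floor lies within the scatter), and because that floor lies within the scatter, the two compounds cannot be ranked. Compound 1 remains only a limit: the limit of > 30000 nM in this assay, at which 1 of the 3 values shown sits.

The compounds shown leave open whether the loss follows the change from methoxy to methyl or the change in ring pattern. A 3,5-dimethylphenyl or 2,4-dimethoxyphenyl group would separate these two changes.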